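A chain methyl on compound 2

This account rests on a few compounds, and the source may have more. Where it says the series, first, only, none or still open, it means among the compounds named here.

Values in a functional assay on the whole organism for agonist activity, with Mus musculus as the target; on this read-out lower numbers stand for an effect already at smaller amounts and higher numbers for an effect only at larger amounts of compound:
compound 1 `CC(=O)N(C)CC#CCn1ccnc1`: 0.97 mg/kg
compound 2 `COC(=O)N(C)CC#CCn1ccnc1`: 2 mg/kg
compound 3 `COC(=O)N(C)CC#CCn1cncc1C`: 4.5 mg/kg

Compound 2 holds the middle of the three numbers, with compound 1 lower and compound 3 higher, both gaps lying beyond the scatter. Compound 4 `COC(=O)N(C)C(C)C#CCn1ccnc1` has not yet been measured. It differs from compound 2 by methyl in place of hydrogen on a saturated chain carbon bound to an amide-type nitrogen and a triple-bonded carbon.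

Among the compounds with values here, no measured compound carries a group on this chain carbon, so the data offer no direct precedent. The nearest guide is a 2.3-fold higher number from compound 2 to compound 3 (0.35 log units; beyond the scatter), a modest step that also puts methyl in place of hydrogen, though on an aromatic carbon. The other measured step, a 2.1-fold higher number from compound 1 to compound 2 (0.31 log units; beyond the scatter), is also modest, but it comes from methoxy in place of methyl on a carbonyl carbon and speaks only to the usual step size in this small set. On that basis, a modest move to a higher number is expected in this assay, with wide uncertainty. The expected step is a 2.5-fold higher number from compound 2 to compound 4 (0.40 log units; beyond the scatter). For compound 4 the estimate is 5 mg/kg, with an expected range of 1.5 mg/kg to 20 mg/kg.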

Compound 4, dose for half-maximal effect: 6.6 mg/kg
Compound 4: the middle estimate sits 1.3-fold (0.12 log units) below what was measured; the measured number falls inside the stated range.
By their numbers in this assay, from the lowest: compound 1; then compound 2; then compounds 3 and 4 (each within the scatter of the next).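

In this assay, the saturated chain carbon bound to an amide-type nitrogen and a triple-bonded carbon is not a neutral place for substitution: a single added methyl gives a 3.3-fold higher number from compound 2 to compound 4 (0.52 log units; beyond the scatter). The aromatic carbon had already given a 2.3-fold higher number from compound 2 to compound 3 (0.35 log units; beyond the scatter), so in the compounds shown, methyl in place of hydrogen leads to a higher number at both places, with no compound here going against this; compound 3 and compound 4 differ in two places, so the two positions are not ranked against each other. No supporting data bear on what lies behind the step at the chain carbon.

Going by these compounds, it remains open whether an ethyl or a hydroxymethyl on this chain carbon would continue the move to higher numbers, or whether a tolerated group exists at this place at all. Also open, on these data alone, are whether the chain methyl gives a similar step on compound 1, which carries methyl rather than methoxy on the carbonyl carbon, and how the chain and aromatic methyl groups behave together on one compound.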